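Compound 4 Expected to Remain Beyond the Toxicity Limit

The source may report more compounds than this note shows. Statements on the series, on what has been measured and on what is new or still open speak of the compounds shown alone.

Of the compounds shown here, three sharing one core have been tested in a toxicity assay on Vero cells (Chlorocebus sabaeus) for inhibition; a higher number here means that more compound is needed for the effect, a lower number that less compound is needed. Compound 1 `COc1cccc(NC(=O)c2nnn(Cc3ccc(SC)cc3)c2N)c1` gives only a limit there, > 50100 nM. Compound 2 `COc1cccc(NC(=O)c2nnn(CC3CCN(C(C)=O)CC3)c2N)c1` likewise gives only a limit, > 50100 nM. Compound 3 `COc1cccc(NC(=O)c2nnn(Cc3ccc(C#N)cc3)c2N)c1` also stands at a limit, > 50100 nM, so its place among the three cannot be ranked. The measured steps a step that the two limits leave unreadable from compound 1 to compound 2, a step that the two limits leave unreadable from compound 1 to compound 3 and a step that the two limits leave unreadable from compound 2 to compound 3 are all unreadable because of the limit of > 50100 nM in this assay, at which 3 of the 3 values shown sit. Compound 4 `COc1cccc(NC(=O)c2nnn(Cc3ccc([S+](C)[O-])cc3)c2N)c1` differs from compound 3 in one place: a group of 3 heavy atoms (1 carbon, 1 oxygen, 1 sulfur; no ring) in place of a group of 2 heavy atoms (1 carbon, 1 nitrogen; no ring), on an aromatic carbon. Within the data shown here, no measured step bears readably on this change, and every value shown is a limit, so no step beyond the scatter is expected: a step that the limit leaves unreadable from compound 3 to compound 4. Compound 4 is therefore estimated at 80000 nM, with a range from 35000 nM to 200000 nM, most likely reported again only as a limit.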

Compound 4, half-maximal effective concentration: > 50100 nM
Compound 4 was reported as a limit (the forecaster's own chance of this, stated with the estimate: 85%); the middle value lies beyond the limit too.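

Compound 4 gives no readable step against compound 1, compound 2 or compound 3, because all four stand at one limit: the limit of > 50100 nM in this assay, at which 4 of the 4 values shown sit.

The compounds shown leave open whether any of these groups on the shared core would give a measurable value in this assay.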